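Removing the Ester From the Only Active Compound

This account rests on a few compounds, and the source may have more. Where it says the series, first, only, none or still open, it means among the compounds named here.

Measured so far:
compound 1 `CCOC(=O)C(C)CN1C(=O)c2ccccc2C1=O` gives 0%
compound 2 `CCCOC(=O)C(C)ON1C(=O)c2ccccc2C1=O` gives 64%
compound 3 `CCOC(=O)C(C)(C)ON1C(=O)c2ccccc2C1=O` gives 0%

All three were tested in a functional assay on the whole organism for inhibition, with Lepidium sativum as the target, tested at 1 ppm; a lower number here means less inhibition of growth, a higher number more inhibition of growth at the concentration tested. Compound 2 stands highest of the three numbers; compound 1 and compound 3 both lie far below it, beyond the scatter, and show no inhibition at all. Compound 4 `CCCC(C)ON1C(=O)c2ccccc2C1=O` has not yet been measured. It differs from compound 2 in one place: propyl in place of propoxycarbonyl on a saturated chain carbon bound to an oxygen on an unsaturated carbon and a saturated chain carbon. Among the measured compounds shown here, no pair of measured compounds shows this exact change, so the data give no direct guide to its effect. For the measured compounds named here, compound 2 is the only compound with any activity, and its ester is taken away here. A downward step a number 39 percentage points lower from compound 2 to compound 4 (beyond the scatter) is expected, of a size beyond the scatter. Compound 4 is estimated at 25%, within 0% to 60%.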

Compound 4, percent growth inhibition at one concentration: 0%
For compound 4 the middle estimate is 25 percentage points above the measured one, and the stated range covers the measured number.
By their numbers in this assay, from the lowest: compounds 1, 3 and 4 (each within the scatter of the next); then compound 2.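

In this assay putting propyl in place of propoxycarbonyl on this saturated chain carbon gives a number 64 percentage points lower from compound 2 to compound 4 (beyond the scatter) and leaves no measurable inhibition. Among the compounds shown here, this is the first direct reading at this position: in this pair, the ester cannot be replaced by a plain propyl chain without losing the activity. Nothing available explains the loss. On these data alone, whether a carboxylic acid or an amide at this place would keep any of the inhibition remains open. So does whether a longer ester would match or exceed compound 2.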